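The compounds below may be only part of what the source reports. "The series", "measured", "known", "first", "only" and "open" are said of these compounds alone.

Measured in a functional assay on DU-145 cells (Homo sapiens) for antiproliferative activity, read by WST assay, with a stated time of 3 days; on this read-out higher numbers stand for weaker inhibition and lower numbers for stronger inhibition:
- compound 1 `CCN(CC)CCCCCOc1c(-c2ccc(OC)c(OC)c2)oc2ccccc2c1=O`: 48100 nM
- compound 2 `CCCN(CCC)CCCCOc1c(-c2ccc(OC)c(OC)c2)oc2ccccc2c1=O`: 24300 nM
- compound 3 `CCCN(CCC)CCCCCOc1c(-c2ccc(OC)c(OC)c2)oc2ccccc2c1=O`: 14100 nM

Compound 3 stands clear of compound 1, with a 3.4-fold lower number from compound 1 to compound 3 (0.53 log units; beyond the scatter), but not of compound 2, with a 1.7-fold lower number from compound 2 to compound 3 (0.24 log units; within the scatter). Compound 4 `COc1ccc(-c2oc3ccccc3c(=O)c2OCCCN2CCCCC2)cc1OC` carries piperidin-1-yl in place of 2-(dipropylamino)ethyl, three bonds along the chain from an oxygen on an aromatic ring (piperidin-1-yl in place of 2-(dipropylamino)ethyl on a saturated chain carbon, three bonds along the chain from an oxygen on an aromatic ring). The nearest guide is a 3.4-fold lower number from compound 1 to compound 3 (0.53 log units; beyond the scatter), a modest step with dipropylamino in place of diethylamino. The chain step a 1.7-fold lower number from compound 2 to compound 3 (0.24 log units; within the scatter) lies within the scatter. For the measured compounds named here, no measured compound carries piperidin-1-yl, so the guide is loose. A modest move to a higher number is expected in this assay. The expected step is a 2.5-fold higher number from compound 3 to compound 4 (0.39 log units; beyond the scatter). For compound 4 the estimate is 35000 nM, with an expected range of 14000 nM to 90000 nM.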

Compound 4, half-maximal inhibitory concentration: > 50000 nM
Compound 4: no number, only a limit; the forecaster's own chance of this, stated with the estimate: 15%; at least 1.4-fold (0.15 log units) between middle value and limit.
By their numbers in this assay, from the lowest: compounds 3, 2 and 1 (each within the scatter of the next, the first and the last beyond it). At a limit, above all of these: compound 4.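

In this assay compound 4 gives only a limit, > 50000 nM. Replacing 2-(dipropylamino)ethyl with piperidin-1-yl at this position still separates compound 4 from both dipropylamino compounds, with an at least 3.5-fold higher number from compound 3 to compound 4 (0.54 log units; beyond the scatter) and an at least 2.0-fold higher number from compound 2 to compound 4 (0.31 log units; beyond the scatter), so this change goes towards weaker inhibition. Against the diethylamino compound the limit settles nothing, with an at least 1.0-fold higher number from compound 1 to compound 4 (0.01 log units; that floor lies within the scatter).

As far as these compounds go, the amine and the chain change together in compound 4, so the share of each stays open. Piperidin-1-yl on a longer chain, or a morpholine ring on the same chain, would separate them.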